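A few compounds are considered here, and "the series" means these few. Any claim that something is new, unique, unknown or untested is made for them only; others in the source may bear on it.

Working notes on the series. In a functional assay on Bel-7402 cells (Homo sapiens) for cytotoxicity, read by MTT assay (a higher number here means a weaker inhibitor, a lower number a stronger inhibitor), compound 1 (`CCn1cc(-c2nc3ccc([N+](=O)[O-])cc3o2)c(=O)c2cc(F)c(N3CCNC(C)C3)c(F)c21`) gives 1600 nM, compound 2 (`CCn1cc(C(=O)Nc2cccc([N+](=O)[O-])c2)c(=O)c2cc(F)c(N3CCNC(C)C3)c(F)c21`) gives 1000 nM and compound 3 (`CCn1cc(C(=O)Nc2cc([N+](=O)[O-])ccc2F)c(=O)c2cc(F)c(N3CCNC(C)C3)c(F)c21`) gives 2900 nM. Compounds 1 and 2 lie within the scatter of each other, while compound 3 stands clearly higher than compound 2.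

Compound 4 (`CCn1cc(C(=O)Nc2ccc(OC(F)(F)F)cc2)c(=O)c2cc(F)c(N3CCNC(C)C3)c(F)c21`) is not yet measured. It has 4-(trifluoromethoxy)phenyl in place of 3-nitrophenyl on an amide-type nitrogen.

Going by the values given here, only one measured step bears on this change: a 2.9-fold higher number from compound 2 to compound 3 (0.46 log units; beyond the scatter), with fluoro in place of hydrogen on an aromatic carbon. Among the compounds with values here, that step is modest and only a rough guide, since it leaves the 3-nitrophenyl group's nitro substituent in place and no measured compound carries the entering group. A modest upward move in this assay is therefore expected, resting on that single step of a 2.9-fold higher number from compound 2 to compound 3 (0.46 log units; beyond the scatter). The expected move is a 1.8-fold higher number from compound 2 to compound 4 (0.26 log units; within the scatter). For compound 4 the estimated value is 1800 nM, with an expected range of 600 nM to 5500 nM.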

Compound 4, half-maximal inhibitory concentration: 2000 nM
The estimate for compound 4 lay 1.1-fold (0.05 log units) below the measured number, within the range that was stated.
By their numbers in this assay, from the lowest: compounds 2, 1, 4 and 3 (each within the scatter of the next, the first and the last beyond it).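

On the amide-type nitrogen, 4-(trifluoromethoxy)phenyl is the first group shown without a nitro substituent, and in this assay it stays within the scatter of both nitro-bearing amides: a 2.0-fold higher number from compound 2 to compound 4 (0.30 log units; within the scatter), and a 1.5-fold lower number from compound 3 to compound 4 (0.16 log units; within the scatter). A nitro substituent on this aryl group is therefore not required for a number in this range, although the swap cannot be ranked against either amide, even though compound 2 and compound 3 lie beyond the scatter of each other. No accompanying measurement bears on why this replacement reads as it does.

Open, going by these compounds, is how a simple alkyl chain on that nitrogen, or a phenyl ring bearing a carboxylic acid or an amine, would read. Equally open, on these data alone, is unsubstituted phenyl, which would give a common reference for the nitro-bearing groups and 4-(trifluoromethoxy)phenyl.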